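Methylating the Oxime Hydroxyl of a Nucleoside Core

A few compounds are considered here, and "the series" means these few. Any claim that something is new, unique, unknown or untested is made for them only; others in the source may bear on it.

Of the compounds shown here, three sharing one core have been tested in a functional assay on KB cells (Homo sapiens) for cytotoxicity, read by spectrophotometry and crystal violet staining; on this read-out higher numbers stand for weaker inhibition and lower numbers for stronger inhibition. Compound 1 `N/C(=N\O)c1c(Br)n(C2O[C@H](CO)[C@@H](O)[C@H]2O)c2cc(Cl)c(Cl)cc12` gives 35000 nM, compound 2 `N/C(S)=N/N=C/c1c(Cl)n(C2O[C@H](CO)[C@@H](O)[C@H]2O)c2cc(Cl)c(Cl)cc12` gives 65000 nM, and compound 3 `OC[C@H]1OC(n2c(Cl)c(/C=N/O)c3cc(Cl)c(Cl)cc32)[C@H](O)[C@@H]1O` gives 25000 nM. Compound 3 has the lowest of the three numbers; its gap to compound 1 is within the scatter, whereas the change between the other two gave a 2.6-fold lower number from compound 2 to compound 3 (0.41 log units; beyond the scatter), a modest shift. Compound 4 `CO/N=C/c1c(Cl)n(C2O[C@H](CO)[C@@H](O)[C@H]2O)c2cc(Cl)c(Cl)cc12` differs from compound 3 by methyl in place of hydrogen on an oxygen. Within the data shown here, no measured step alters this oxygen itself; the only related step is the one from compound 2 to compound 3, which exchanged the whole group on the double-bonded nitrogen and was modest. Since a single methyl is a far smaller change, compound 4 is expected to show no step beyond the scatter, an estimated 1.1-fold higher number from compound 3 to compound 4 (0.05 log units; within the scatter). Compound 4 is therefore estimated at 28000 nM, with a likely range from 10000 nM to 80000 nM.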

Compound 4, half-maximal inhibitory concentration: 70000 nM
For compound 4 the middle estimate is 2.5-fold (0.40 log units) below the measured one; measured number inside the range.
By their numbers in this assay, from the lowest: compounds 3, 1, 2 and 4 (each within the scatter of the next, the first and the last beyond it).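

In this assay, swapping hydroxy for methoxy on this oxygen is the smallest possible edit, yet it gives a 2.8-fold higher number from compound 3 to compound 4 (0.45 log units; beyond the scatter), so this hydrogen is not a silent spot on the molecule. Replacing the larger group on the double-bonded nitrogen with methoxy gives a 1.1-fold higher number from compound 2 to compound 4 (0.03 log units; within the scatter), which means that the two groups cannot be told apart in this test. Nothing at hand explains why the methyl matters here. 

Still open, on these data alone, is whether a longer chain, such as ethyl, on this oxygen would move the number further. Also open, as far as these compounds go, is whether an amine on the double-bonded nitrogen, in place of the oxygen, would stay close to compound 3.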